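From Propyl to 2-Hydroxyethyl on the Amide Chain

This account rests on a few compounds, and the source may have more. Where it says the series, first, only, none or still open, it means among the compounds named here.

For the measured compounds named here, in a functional assay on Huh-5-2 cells (Homo sapiens), read by MTT assay (a higher number here means that more compound is tolerated, a lower number that less compound is tolerated), compound 1 `CN(C)C(=O)c1ccc(-c2ccc(Cl)cc2)c(COc2ccc(-c3nc4cc(C(=O)O)ccc4n3C3CCCCC3)cc2)c1` gives 28000 nM and compound 2 `CCCNC(=O)c1ccc(-c2ccc(Cl)cc2)c(COc2ccc(-c3nc4cc(C(=O)O)ccc4n3C3CCCCC3)c(F)c2)c1` gives 24000 nM, so compound 2 stands within the scatter of the only other measured compound. Compound 3 `O=C(O)c1ccc2c(c1)nc(-c1ccc(OCc3cc(C(=O)NCCO)ccc3-c3ccc(Cl)cc3)cc1F)n2C1CCCCC1` differs from compound 2 by hydroxy in place of methyl on a saturated chain carbon, two bonds along the chain from an amide-type nitrogen, which turns propyl into 2-hydroxyethyl. Going by the values given here, no measured step covers this change, so no step beyond the scatter is expected in this assay. The expected change is small, with the estimate amounting to a 1.2-fold higher number from compound 2 to compound 3 (0.07 log units; within the scatter). Compound 3 is estimated at 28000 nM, with an expected range of 14000 nM to 55000 nM.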

Compound 3, half-maximal cytotoxic concentration: 26000 nM
Compound 3: the middle estimate sits 1.1-fold (0.03 log units) above what was measured; the range from low to high includes it.
By their numbers in this assay, from the lowest: compounds 2, 3 and 1 (each within the scatter of the next).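

In this assay, the change from propyl to 2-hydroxyethyl on the amide chain gives a 1.1-fold higher number from compound 2 to compound 3 (0.03 log units; within the scatter). This first step read at this position shows that hydroxy in place of methyl, on a saturated chain carbon two bonds along the chain from an amide-type nitrogen, leaves the number within the scatter. No measured property is at hand to account for this result. As far as these compounds go, whether an amine or a carboxylic acid on this chain, or a longer chain ending in hydroxy, would also stay within the scatter remains open.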